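Methyl on the amine nitrogen of compound 3

The source may report more compounds than this note shows. Statements on the series, on what has been measured and on what is new or still open speak of the compounds shown alone.

Measured in a functional assay on V79 cells (Cricetulus griseus) for cytotoxicity, read by colony formation; a lower number here means a stronger inhibitor, a higher number a weaker inhibitor:
- compound 1 `CC1(CN)CCN(c2cc3c(cc2F)c(=O)c(C(=O)O)cn3C2CC2)C1`: 23 ug/mL
- compound 2 `CC1(CN)CCN(c2c(F)cc3c(=O)c(C(=O)O)cn(C4CC4)c3c2Cl)C1`: 8 ug/mL
- compound 3 `CC1(CN)CCN(c2c(F)cc3c(=O)c(C(=O)O)cn(C4CC4)c3c2C(F)(F)F)C1`: 110 ug/mL

Of these three, compound 3 has the highest number, 110 ug/mL, which makes it the weakest inhibitor in this assay. The measured steps show this as a 4.8-fold higher number from compound 1 to compound 3 (0.68 log units; beyond the scatter) and a 14-fold higher number from compound 2 to compound 3 (1.14 log units; beyond the scatter). The third step is a 2.9-fold lower number from compound 1 to compound 2 (0.46 log units; beyond the scatter).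

Compound 4 `CNCC1(C)CCN(c2c(F)cc3c(=O)c(C(=O)O)cn(C4CC4)c3c2C(F)(F)F)C1` is the next structure to be tested. It differs from compound 3 by methyl in place of hydrogen on an amine nitrogen. All three measured steps are changes on an aromatic carbon, from modest to large, and none of them touches the amine nitrogen. They therefore give no direct guide to the size or direction of this change, and no step beyond the scatter is expected in this assay. The estimate is a 1.1-fold lower number from compound 3 to compound 4 (0.04 log units; within the scatter). Compound 4 is expected at 100 ug/mL, with an estimated range from 40 ug/mL to 250 ug/mL.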

Compound 4, half-maximal inhibitory concentration: 230 ug/mL
The estimate for compound 4 lay 2.3-fold (0.36 log units) below the measured number, and the stated range covers the measured number.
By their numbers in this assay, from the lowest: compound 2; then compound 1; then compound 3; then compound 4.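

In this assay, methyl in place of hydrogen on the amine nitrogen moves the number beyond the scatter (a 2.1-fold higher number from compound 3 to compound 4 (0.32 log units; beyond the scatter)), so this nitrogen is a place where a single added carbon changes the read-out, which the steps on the aromatic carbon could not show. The change is modest in size and goes toward a weaker inhibitor, with 3-methyl-3-((methylamino)methyl)pyrrolidin-1-yl reading less strongly than 3-(aminomethyl)-3-methylpyrrolidin-1-yl. Nothing available explains this shift.

Within the data shown here, the step is seen only with trifluoromethyl on the aromatic carbon, so whether methyl on the amine nitrogen acts alike with chloro or hydrogen there, as in compound 2 and compound 1, stays open. Also open, from the compounds shown here alone, is how an ethyl group or a longer chain on that nitrogen would read in this assay.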